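A few compounds are considered here, and "the series" means these few. Any claim that something is new, unique, unknown or untested is made for them only; others in the source may bear on it.

For the measured compounds named here, compound 1 `ClCc1ccccc1Cn1cnc2c(Cl)nc(Cl)nc21` is one of three compounds measured in a functional assay on RPMI-8226 cells (Homo sapiens) for cytotoxicity, read by sulforhodamine B assay, with a stated time of 48 h; on this read-out lower numbers stand for stronger inhibition of growth and higher numbers for weaker inhibition of growth. Compound 1 gives 380 nM, the lowest number of the three. Compound 3 `ClCc1cccc(Cn2cnc3nc(Cl)nc(Cl)c32)c1` gives 1690 nM, and compound 2 `ClCc1cccc(Cn2cnc3ncnc(Cl)c32)c1` gives 13800 nM, so compound 1 stands well apart from both.

Compound 4 `Nc1nc(Cl)c2ncn(Cc3ccccc3CCl)c2n1` has not yet been measured. It differs from compound 1 in one place: amino in place of chloro on an aromatic carbon. Going by the values given here, the only measured step that bears on this spot is the one from compound 2 to compound 3, where chloro replaced hydrogen on an aromatic carbon and gave an 8.2-fold lower number from compound 2 to compound 3 (0.91 log units; beyond the scatter). That step shows the chloro group at this kind of position matters, though it was read in a pair with a different benzyl substitution, and amino is not hydrogen, so the comparison is indirect. Taking the chloro away is therefore expected to cost some potency, with a 3.9-fold higher number from compound 1 to compound 4 (0.60 log units; beyond the scatter) as the estimated step. Compound 4 is expected to give about 1500 nM, within a range of 400 nM to 6000 nM.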

Compound 4, concentration for 50% growth inhibition: 11200 nM
The estimate for compound 4 lay 7.5-fold (0.87 log units) below the measured number; the measured number lies above the stated range.
By their numbers in this assay, from the lowest: compound 1; then compound 3; then compounds 4 and 2 (each within the scatter of the next).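

In this assay, amino in place of the chloro group between two ring nitrogen atoms gives a 29-fold higher number from compound 1 to compound 4 (1.47 log units; beyond the scatter) and so a large loss of growth inhibition on this benzyl pattern. The earlier step, an 8.2-fold lower number from compound 2 to compound 3 (0.91 log units; beyond the scatter), showed a gain from chloro in place of hydrogen, but on a different benzyl pattern; this new step shows directly that, with the benzyl group of compound 1, the chloro group cannot be exchanged for amino without a large change in the number. Nothing in the data shown explains the size of this loss.

From the compounds shown here alone, it remains open how a methoxy or methyl group would behave at this position. Going by these compounds, it is also open whether amino in place of chloro would have a similar effect on the benzyl pattern of compound 3.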